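The source may report more compounds than this note shows. Statements on the series, on what has been measured and on what is new or still open speak of the compounds shown alone.

Measured so far:
compound 1, `COc1cc(C)cc(-c2nn(CC#N)cc2-c2ccc(-c3cccc(C(C)=O)c3)nc2)c1`, 3610 nM
compound 2, `Cc1cc(O)cc(-c2nn(CC#N)cc2-c2ccnc(-c3ccc(Oc4ccccc4)cc3)c2)c1`, 2380 nM
compound 3, `COc1cc(C)cc(-c2nn(CC#N)cc2-c2ccnc(-c3ccc(N(C)C)cc3)c2)c1`, 448 nM

In a functional assay on UACC-257 cells (Homo sapiens) for inhibition, read by sulforhodamine B assay, with a stated time of 48 h (on this read-out lower numbers stand for stronger inhibition of growth and higher numbers for weaker inhibition of growth), compound 3 gives the lowest of the three numbers. Its nearest neighbour on the numbers is compound 2, whose value stands beyond the scatter above it, and compound 1 stands further away still. The three compounds differ in more than one place, so no single change among them can be read off as a step.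

Compound 4, `Cc1cc(O)cc(-c2nn(CC#N)cc2-c2ccnc(-c3ccc(N(C)C)cc3)c2)c1`, is not yet measured. It keeps the dimethylamino-bearing arm of compound 3 and differs only on the other ring: hydrogen in place of methyl on an oxygen on an aromatic ring. Compound 2 carries the same hydroxy-bearing ring, but its other arm differs, so its value does not measure this change on its own.

No step of this kind is shown here, so the expectation for compound 4 in this assay rests on the value of compound 3 alone; a step of a 1.5-fold higher number from compound 3 to compound 4 (0.16 log units; within the scatter) is expected, which is to say no change beyond the scatter, with a slight lean toward a higher number. Compound 4 is thus estimated at 650 nM, within 250 nM to 1700 nM.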

Compound 4, concentration for 50% growth inhibition: 4350 nM
Compound 4: the middle estimate sits 6.7-fold (0.83 log units) below what was measured; measured number outside the range, above it.
By their numbers in this assay, from the lowest: compound 3; then compounds 2, 1 and 4 (each within the scatter of the next).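

In this assay the methoxy of the 3-methoxy-5-methylphenyl ring proves to matter: hydroxy in its place gives a 9.7-fold higher number from compound 3 to compound 4 (0.99 log units; beyond the scatter) with the dimethylamino arm kept. Among the compounds shown here, this is the first single change read at this position, and it shows that losing the methyl from that oxygen costs growth inhibition beyond the scatter. With the hydroxy-bearing ring kept, dimethylamino in place of phenoxy on an aromatic carbon gives a 1.8-fold higher number from compound 2 to compound 4 (0.26 log units; within the scatter) and so does not separate the two compounds.

Nothing measured here accounts for the effect of that methyl. Going by these compounds, whether an ethoxy group, a fluorine or an amine at this place would hold the number of compound 3 remains open, as does whether methoxy to hydroxy costs the same with the phenoxy arm.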